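Aryl group on the piperazine-type ring nitrogen: working notes

The compounds below may be only part of what the source reports. "The series", "measured", "known", "first", "only" and "open" are said of these compounds alone.

Measured so far in an assay on CHO cells for displacement of a labelled ligand from adenosine receptor A1 (Homo sapiens), read by scintillation counting, with a stated time of 120 min, tested at 10 uM; on this read-out higher numbers stand for more inhibition at the one concentration tested (going by the name of the read-out) and lower numbers for less inhibition:
compound 1, `Nc1scc(CN2CCN(c3ccc(Cl)cc3Cl)CC2)c1C(=O)c1ccc(Cl)cc1`: 0%
compound 2, `Nc1scc(CN2CCN(c3cccc(Cl)c3Cl)CC2)c1C(=O)c1ccc(Cl)cc1`: 2%
compound 3, `Nc1scc(CN2CCN(c3cccc4ccccc34)CC2)c1C(=O)c1ccc(Cl)cc1`: 1%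

All three compounds share one core and differ only in the aryl group carried by the amine nitrogen in the ring. In this assay compound 1 gives 0%, compound 2 gives 2% and compound 3 gives 1%. Compound 3 holds the second highest of the three numbers, but the gap to its nearest neighbour, a number 1 percentage points higher from compound 1 to compound 3 (within the scatter), and the gap to the furthest, a number 1 percentage points lower from compound 2 to compound 3 (within the scatter), both lie within the scatter, so no order among the three can be read from these values. The third measured step, a number 2 percentage points higher from compound 1 to compound 2 (within the scatter), is likewise within the scatter.

Compound 4, `Nc1scc(CN2CCN(c3c(F)cc(F)cc3F)CC2)c1C(=O)c1ccc(Cl)cc1`, remains to be measured. Its change from compound 3 is 2,4,6-trifluorophenyl in place of naphthalen-1-yl on an amine nitrogen in a ring. All three measured steps concern the same site, an exchange of one aryl group for another on the amine nitrogen in the ring, and none of them moved the read-out beyond the scatter. The expectation for compound 4 is therefore a step of no change at the digits printed from compound 3 to compound 4 (within the scatter), that is, nothing beyond the scatter. The estimate for compound 4 in this assay is 1%, with a range from -6% to 10%.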

Compound 4, a percentage reported as inhibition, at one concentration (the size of the read-out at that concentration, not a potency): 0%
Estimate against measurement, compound 4: 1 percentage points above; the measured number falls inside the stated range.
By their numbers in this assay, from the lowest: compounds 1, 4, 3 and 2 (each within the scatter of the next).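

In this assay, the exchange of the two-ring naphthalen-1-yl for the one-ring 2,4,6-trifluorophenyl gives a number 1 percentage points lower from compound 3 to compound 4 (within the scatter), and the exchanges of the two dichlorophenyl groups for the same group give a number 2 percentage points lower from compound 2 to compound 4 (within the scatter) and no change at the digits printed from compound 1 to compound 4 (within the scatter). The earlier compounds shown here covered only chlorine-bearing and two-ring aryl groups at this position; with fluorine as the ring substituent, the number still stays within the scatter of all three, so the four aryl groups cannot be put in any order. No measured data bear on the reason for this flat result.

The compounds shown leave open whether an aryl group carrying an amine or a carboxylic acid, or a longer alkyl chain in place of the aryl group on this ring nitrogen, would move the number in this assay beyond the scatter. They also leave open whether a change elsewhere on the shared core, such as on the 4-chlorobenzoyl group, would do so, with the aryl group on the ring nitrogen held fixed.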